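The source may hold more compounds than are shown below. What is called first, only, known or untested is meant among the compounds shown, and "the series" means these compounds.

Among the measured compounds shown here, two measured amides define the series so far. In a functional assay on 786-0 cells (Homo sapiens) for antiproliferative activity, read by sulforhodamine B assay, with a stated time of 48 h (on this read-out lower numbers stand for stronger inhibition of growth and higher numbers for weaker inhibition of growth), compound 1 `CCCCCCCC/C=C\CCCCCCCC(=O)N1CCCCC1` gives 10.6 ug/mL, the lowest of the two numbers. Compound 2 `CCCCCCCCCCCCCCCCCC(=O)N1CCCC1` gives 14 ug/mL in this assay, and the gap between the two values lies within the scatter of repeated measurements, so no order between them is claimed.

The next compound, compound 3 `CCCCC/C=C\C/C=C\CCCCCCCC(=O)N1CCCCC1`, keeps the amide and the core of compound 1 and differs in the chain only: hept-1-en-1-yl in place of heptyl on a saturated chain carbon bound to a double-bonded chain carbon. No measured pair isolates this change, so the expectation rests on compound 1 alone and on the chain difference, with no shown step to lean on. The step of a 1.3-fold lower number from compound 1 to compound 3 (0.12 log units; within the scatter) is expected to be small, if anything toward a lower number, and may not exceed the scatter. Compound 3 is estimated in this assay at 8 ug/mL, within a range from 4 ug/mL to 16 ug/mL.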

Compound 3, concentration for 50% growth inhibition: 58.4 ug/mL
The estimate for compound 3 lay 7.3-fold (0.86 log units) below the measured number, outside the stated range (above it).
By their numbers in this assay, from the lowest: compounds 1 and 2 (each within the scatter of the next); then compound 3.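

In this assay, among the compounds shown here, hept-1-en-1-yl in place of heptyl on a saturated chain carbon bound to a double-bonded chain carbon gives the first single-change step (a 5.5-fold higher number from compound 1 to compound 3 (0.74 log units; beyond the scatter)). Compounds 1 and 2 differ in more than one place and could not show this; here, one added double bond in the chain goes with weaker inhibition of growth, and the step lies beyond the scatter. No available measurement bears on the reason for this step.

The compounds shown leave open whether the step belongs to this double bond alone, since a single pair cannot separate its presence from its place in the chain. Also open, going by these compounds, is how a longer chain, or a hydroxyl group on the chain, would read at this position.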